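From Cyclopropylamine to Piperidine: What Compound 4 May Show

The source may report more compounds than this note shows. Statements on the series, on what has been measured and on what is new or still open speak of the compounds shown alone.

Compound 1 `CCCc1ccc(NC2=CC(=O)c3c(nc4n3[C@H]3OC[C@@H](O)[C@H]3OC4)C2=O)cc1`: 6030 nM in a functional assay on HeLa cells (Homo sapiens) for inhibition, read by sulforhodamine B assay; on this read-out lower numbers stand for stronger inhibition and higher numbers for weaker inhibition
Compound 2 `Cc1ccc(NC2=CC(=O)c3c(nc4n3[C@H]3OC[C@@H](O)[C@H]3OC4)C2=O)cc1C`: 4320 nM
Compound 3 `O=C1C(NC2CC2)=CC(=O)c2c1nc1n2[C@H]2OC[C@@H](O)[C@H]2OC1`: > 16000 nM

Compound 3 stands at the weak end of the three: its value in this assay is a limit, not a number. It sits at the limit of > 16000 nM in this assay, at which 1 of the 3 values shown sits. The values of compound 1 and compound 2 lie within the scatter of each other. Compound 4 `O=C1C(N2CCCCC2)=CC(=O)c2c1nc1n2[C@H]2OC[C@@H](O)[C@H]2OC1` differs from compound 3 by piperidin-1-yl in place of cyclopropylamino on a double-bonded ring carbon. Among the measured compounds shown here, two measured steps bear on this change: an at least 2.6-fold higher number from compound 1 to compound 3 (0.42 log units; beyond the scatter) and an at least 3.7-fold higher number from compound 2 to compound 3 (0.56 log units; beyond the scatter), each replacing an aromatic group on the amine nitrogen with a small non-aromatic ring, and each weakening beyond the scatter. Compound 4 again carries a non-aromatic ring and no aromatic group, so no gain is expected, and the result may once more come back only as a limit. Compound 4 is expected to give about 16000 nM, between 8000 nM and 40000 nM. This expectation means a number no higher from compound 3 to compound 4 (the limit leaves the size open), a step within the scatter.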

Compound 4, half-maximal inhibitory concentration: > 16000 nM
Compound 4: a limit, no number; the forecaster's own chance of this, stated with the estimate: 70%; the middle value lies on the limit itself.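

Piperidin-1-yl carries no hydrogen-bond donor, unlike cyclopropylamino, yet the change gives no readable gain in this assay, and the step between the two limits cannot be read. Set against the aromatic amine, the change gives an at least 3.7-fold higher number from compound 2 to compound 4 (0.56 log units; beyond the scatter). Among the four compounds, both without an aromatic group now sit at the assay's limit, so a second non-aromatic ring, larger than the first, gives no measurable number: the limit of > 16000 nM in this assay, at which 2 of the 4 values shown sit.

On these data alone, how far compound 3 and compound 4 lie beyond that limit remains open. So does whether a benzylamino or a morpholin-4-yl group on this carbon would give a measurable value.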